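The compounds below may be only part of what the source reports. "The series", "measured", "known", "first", "only" and "open" are said of these compounds alone.

Compound 1 `CNC(=O)CC1CCc2cc(OC)c(OC)cc21` was tested in a functional assay on the whole organism (strain Swiss albino) for inhibition, with Mus musculus as the target, in the writhing test, with stated times of 60 min and 15 min, at a dose of 100 mg/kg by the oral route (a lower number here means less inhibition, a higher number more inhibition at the dose given (going by the name of the read-out)), where compound 1 gives 21.2%. Among the three compounds measured so far, compound 1 stands lowest, though every gap to it is small. Its nearest neighbour is compound 2 `CCNC(=O)CC1CCc2cc(OC)c(OC)cc21`, which gives 23.6%, reached by the step of a number 2.4 percentage points higher from compound 1 to compound 2 (within the scatter). Furthest away is compound 3 `COc1cc2c(cc1OC)C(CC(=O)NC(C)C)CC2`, which gives 29.3%, reached by the step of a number 8.1 percentage points higher from compound 1 to compound 3 (within the scatter). Between those two, the step of a number 5.7 percentage points higher from compound 2 to compound 3 (within the scatter) is likewise small. None of the three changes at the amide end of the molecule moved the number beyond the usual scatter.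

Compound 4 `COc1cc2c(cc1OC)C(CC(=O)NCCO)CC2` has not yet been measured. It differs from compound 1 in one place: hydroxymethyl in place of hydrogen on a saturated chain carbon bound to an amide-type nitrogen. The two measured steps that bear on this are the ones that also alter the group on the amide nitrogen, the step of a number 2.4 percentage points higher from compound 1 to compound 2 (within the scatter) and the step of a number 8.1 percentage points higher from compound 1 to compound 3 (within the scatter), both within the scatter. Among the measured compounds shown here, with no measured step here carrying a hydroxyl group, the expectation can only rest on those small steps, so no step beyond the scatter is expected. Compound 4 is therefore estimated at 24%, with a range from 12% to 36%. The step this estimate implies, a number 2.8 percentage points higher from compound 1 to compound 4 (within the scatter), is expected to lie within the scatter.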

Compound 4, a percentage reported as inhibition, in the whole organism at one dose (the size of the read-out at that dose, not a potency): 29.8%
Compound 4: the middle estimate sits 5.8 percentage points below what was measured; low and high end bracket the measured number.
By their numbers in this assay, from the lowest: compounds 1, 2, 3 and 4 (each within the scatter of the next).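

Among the compounds shown here, compound 4 is the first compound here with a hydroxyl group on the amide side chain, and in this assay all three new comparisons stay within the usual scatter: a number 8.6 percentage points higher from compound 1 to compound 4 (within the scatter) and a number 6.2 percentage points higher from compound 2 to compound 4 (within the scatter) and also a number 0.5 percentage points higher from compound 3 to compound 4 (within the scatter). The group on the amide nitrogen has now been methyl, ethyl, isopropyl and 2-hydroxyethyl, and no pair among these four compounds separates beyond the scatter, so a chain carrying a hydroxyl group cannot be told apart from one without it at this position. No measurement is available that would explain this result.

On these data alone, it remains open whether any group on this nitrogen can move the number beyond the scatter, for example a dimethylamino group, a carboxylic acid or a longer chain ending in hydroxyl. Each number also gives only the size of the effect at one oral dose, not a potency, so these compounds could still differ at other doses.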